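The source may report more compounds than this note shows. Statements on the series, on what has been measured and on what is new or still open speak of the compounds shown alone.

Measured so far in a functional assay on PC-3 cells (Homo sapiens) for cytotoxicity, read by WST assay, with a stated time of 24 h; a higher number here means a weaker inhibitor, a lower number a stronger inhibitor:
Compound 1 `N#C/C(=C\c1c[nH]c2cc(F)ccc12)C(=O)c1c[nH]c2ccccc12` reports only a limit in this assay, > 50000 nM.
Compound 2 `COc1ccc2c(/C=C(\C#N)C(=O)c3c[nH]c4ccccc34)c[nH]c2c1` gives 33300 nM in this assay.
Compound 3 `COc1ccc(Cn2cc(/C=C(\C#N)C(=O)c3c[nH]c4cc(OC)ccc34)c3ccccc32)cc1` reports only a limit in this assay, > 50000 nM.

Within the data shown here, the one counted step runs from compound 2 to compound 1: an at least 1.5-fold higher number from compound 2 to compound 1 (0.17 log units; that floor lies within the scatter), the change being (fluoro in place of methoxy on an aromatic carbon). How the core of compound 3 differs from that of compound 2 is not broken down here.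

Compound 4 `COc1ccc(Cn2cc(/C=C(\C#N)C(=O)c3c[nH]c4cc(F)ccc34)c3ccccc32)cc1` carries the same change against compound 3: fluoro in place of methoxy on an aromatic carbon. The two place descriptions read the same word for word, so this is the same change as from compound 2 to compound 1. The step expected in this assay is a step that the limit leaves unreadable from compound 3 to compound 4, a reading at the limit again, because compound 3 already sits at the limit of > 50000 nM in this assay, at which 2 of the 3 values shown sit. For compound 4 the estimate in this assay is therefore 80000 nM, between 40000 nM and 200000 nM.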

Compound 4, half-maximal inhibitory concentration: > 50000 nM
Compound 4: only a limit was reported; the forecaster's own chance of this, stated with the estimate: 85%; the middle value is on the limit's open side.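

Compound 3 and compound 4 both report only a limit in this assay, so no step between them can be read: the limit of > 50000 nM in this assay, at which 3 of the 4 values shown sit.

On these data alone, whether fluoro in place of methoxy shifts the number on the core of compound 3 remains open.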